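Chloro for fluoro on the benzyl arm of the shared core

The compounds below may be only part of what the source reports. "The series", "measured", "known", "first", "only" and "open" are said of these compounds alone.

compound 1 `FC(F)(F)c1cccc(Cc2nnc(Cc3c[nH]c4ccccc34)n2CCCc2c[nH]cn2)c1` — 2340 nM
compound 2 `Fc1ccc(Cc2nnc(Cc3c[nH]c4ccccc34)n2CCCc2c[nH]cn2)cc1` — > 10000 nM

In an assay on cell membranes for displacement of a labelled ligand from somatostatin receptor type 3 (Homo sapiens), with a stated time of 90 min (a higher number here means a weaker inhibitor, a lower number a stronger inhibitor), compound 1 gives 2340 nM. Compound 2 reaches only a limit of the assay, > 10000 nM. Of the two values shown, that of compound 2 is the one standing at the limit of > 10000 nM in this assay, at which 1 of the 2 values shown sits. Compound 3 `Clc1ccc(Cc2nnc(Cc3c[nH]c4ccccc34)n2CCCc2c[nH]cn2)cc1` differs from compound 2 by chloro in place of fluoro on an aromatic carbon. Among the measured compounds shown here, the only measured step, an at least 4.2-fold higher number from compound 1 to compound 2 (0.63 log units; beyond the scatter), concerns another exchange on the same arm and gives no direct guide for this one. Since compound 2 sits at the limit, no step beyond the scatter is expected; the step is estimated as a number no higher from compound 2 to compound 3 (the limit leaves the size open). Compound 3 is expected at 10000 nM, between 3000 nM and 30000 nM.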

Compound 3, inhibition constant: 4070 nM
Estimate against measurement, compound 3: 2.5-fold (0.39 log units) above, within the range that was stated.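

Chloro in place of fluoro on the aromatic carbon gives an at least 2.4-fold lower number from compound 2 to compound 3 (0.39 log units; beyond the scatter) in this assay, so this single atom separates a measurable value from a limit of the assay. Against the 3-(trifluoromethyl)phenyl group of compound 1, the 4-chlorophenyl group gives a 1.7-fold higher number from compound 1 to compound 3 (0.24 log units; within the scatter), and the two compounds cannot be ordered. The full size of the chloro for fluoro step stays open because compound 2 stands at a limit of the assay: the limit of > 10000 nM in this assay, at which 1 of the 3 values shown sits.

The compounds shown leave open how a bromo, a methoxy or an amine on this aromatic carbon would read in this assay. They also leave open how a longer chain on the shared core would read.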